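The source may hold more compounds than are shown below. What is called first, only, known or untested is meant among the compounds shown, and "the series" means these compounds.

Measured so far:
compound 1 `Cc1ccc(C(=O)N2CC(c3nc(-c4cccc(F)c4)no3)C2)cc1` — > 10000 nM
compound 2 `Cc1ccc(S(=O)(=O)N2CC(c3nc(-c4cccc(C)c4)no3)C2)cc1` — 670 nM
compound 3 `Cc1cccc(-c2noc(C3CN(S(=O)(=O)c4ccc(F)cc4)C3)n2)c1` — 950 nM

In an assay on HEK293 cells for negative allosteric modulation of metabotropic glutamate receptor 5 (Homo sapiens), read by FLIPR (on this read-out higher numbers stand for weaker inhibition and lower numbers for stronger inhibition), compound 1 gives only a limit, > 10000 nM, and this is recorded as the limit of > 10000 nM in this assay, at which 1 of the 3 values shown sits. Compound 2 and compound 3 share one core and differ by fluoro in place of methyl on an aromatic carbon; this change made a 1.4-fold higher number from compound 2 to compound 3 (0.15 log units; within the scatter). The difference between the core of compound 1 and the core of compound 2 is not broken down here.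

Compound 4 `O=C(c1ccc(F)cc1)N1CC(c2nc(-c3cccc(F)c3)no2)C1` has not yet been measured in this assay. It differs from compound 1 by fluoro in place of methyl on an aromatic carbon, the same change that was made from compound 2 to compound 3. Compound 4 is therefore expected to show a step that the limit leaves unreadable from compound 1 to compound 4, an expectation that rests on a 1.4-fold higher number from compound 2 to compound 3 (0.15 log units; within the scatter) and on the limit of compound 1, > 10000 nM. Compound 4 is estimated at 15000 nM, expected to lie between 5000 nM and 50000 nM.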

Compound 4, half-maximal inhibitory concentration: > 10000 nM
Compound 4: only a limit was reported (the forecaster's own chance of this, stated with the estimate: 70%); the middle value is on the limit's open side.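

Compound 1 and compound 4 both stand at a limit, so no step can be read between them: the limit of > 10000 nM in this assay, at which 2 of the 4 values shown sit. The compounds shown leave open whether 4-methylphenyl to 4-fluorophenyl changes inhibition on this core.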